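Dimethylamino replaces the amino-acid terminus: outlook for compound 4

The compounds below may be only part of what the source reports. "The series", "measured", "known", "first", "only" and "open" are said of these compounds alone.

Going by the values given here, compound 3 `CC(C)[C@@H](NC(=O)/C=C/c1ccncc1-c1ccc2ccccc2c1)C(=O)O` gives 77% in an assay on a protein complex for inhibition of CDK8/Cyclin C (Homo sapiens), with a stated time of 1 h, tested at 10 uM (on this read-out lower numbers stand for less inhibition and higher numbers for more inhibition at the one concentration tested (going by the name of the read-out)), the lowest of the three numbers so far. Compound 1 `NNC(=O)CCc1ccncc1-c1ccc2ccccc2c1` gives 102% and compound 2 `COC(=O)/C=C/c1ccncc1-c1ccc2ccccc2c1` gives 102% in this assay; no change at the digits printed from compound 1 to compound 2 (within the scatter). Among the compounds with values here, the only step at the carbonyl carbon is a number 25 percentage points lower from compound 2 to compound 3 (beyond the scatter), where the (1-carboxy-2-methylpropyl)amino group enters. Compound 4 `CN(C)C(=O)/C=C/c1ccncc1-c1ccc2ccccc2c1` carries dimethylamino in place of (1-carboxy-2-methylpropyl)amino on a carbonyl carbon. Within the data shown here, no measured step covers dimethylamino itself; the single step at this position is the modest drop that came with the amino-acid group, and compound 4 removes that group. A rise back toward the values of compounds 1 and 2 is therefore expected, with some chance that compound 4 stays near compound 3. The expected step for compound 4 is roughly a number 18 percentage points higher from compound 3 to compound 4 (beyond the scatter). Compound 4 is estimated at 95%, range 75% to 105%.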

Compound 4, a percentage reported as inhibition, at one concentration (the size of the read-out at that concentration, not a potency): 100%
For compound 4 the middle estimate is 5 percentage points below the measured one; the range from low to high includes it.
By their numbers in this assay, from the lowest: compound 3; then compounds 4, 1 and 2 (each within the scatter of the next).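

In this assay, the lower number at the carbonyl carbon belongs to the (1-carboxy-2-methylpropyl)amino group and not to every nitrogen substituent there (a number 23 percentage points higher from compound 3 to compound 4 (beyond the scatter)). Dimethylamino matches methoxy on this carbon (a number 2 percentage points lower from compound 2 to compound 4 (within the scatter)), and the 2-(dimethylcarbamoyl)ethenyl group matches 2-(aminocarbamoyl)ethyl (a number 2 percentage points lower from compound 1 to compound 4 (within the scatter)). No measurement available here explains the lower number of compound 3.

Open, as far as these compounds go, is whether the carboxylic acid or the branched chain of the leaving group accompanies the drop. A methyl ester of that group, or morpholine on the carbonyl carbon, would bear on this.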